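Oxime ether in place of methoxymethyl on a macrocyclic ketone

A few compounds are considered here, and "the series" means these few. Any claim that something is new, unique, unknown or untested is made for them only; others in the source may bear on it.

The account follows three measured members of one macrocyclic series and one whose number is still outstanding. Compound 1 `COC/C1=C/C[C@](C)(CCC=C(C)C)/C=C/[C@@H](OC(=O)C=C(C)C)[C@](C)(O)/C=C/C1=O` is tested in a functional assay on SMMC-7721 cells (Homo sapiens) for antiproliferative activity, read by MTT assay, with a stated time of 48 h (a higher number here means a weaker inhibitor, a lower number a stronger inhibitor), and gives 11000 nM. Compound 3 `CC(C)=CCC[C@]1(C)/C=C/[C@@H](OC(=O)C=C(C)C)[C@](C)(O)/C=C/C(O)/C(C=O)=C\C1` gives 730 nM in this assay, so compound 1 holds the highest of the two numbers shown, and its gap to compound 3 lies beyond the usual scatter. Compound 2 `CC(C)=CCC[C@]1(C)/C=C/[C@@H](OC(=O)C=C(C)C)[C@](C)(O)/C=C/[C@H](O)/C(CO)=C\C1` returns only a limit of the assay, > 40000 nM, rather than a number (the limit of > 40000 nM in this assay, at which 1 of the 3 values shown sits).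

Compound 4 `CO/N=C/C1=C/C[C@](C)(CCC=C(C)C)/C=C/[C@@H](OC(=O)C=C(C)C)[C@](C)(O)/C=C/C1=O` is the unmeasured partner of compound 1. The change between them is a group of 4 heavy atoms (2 carbon, 1 nitrogen, 1 oxygen; no ring) in place of a group of 3 heavy atoms (2 carbon, 1 oxygen; no ring), on a double-bonded ring carbon. Within the data shown here, no pair of measured compounds differing in exactly one place is available, so the size of this step cannot be read from the data; compound 1 and compound 4 share everything else in the shared core.

Given the limited comparison, a modest shift toward a lower number is expected, with a 1.8-fold lower number from compound 1 to compound 4 (0.26 log units; within the scatter) as the estimated step. Compound 4 is therefore expected to give about 6000 nM in this assay, within a range from 1500 nM to 25000 nM.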

Compound 4, half-maximal inhibitory concentration: 3470 nM
Compound 4: middle estimate off by 1.7-fold (0.24 log units), on the high side, within the range that was stated.
By their numbers in this assay, from the lowest: compound 3; then compound 4; then compound 1. At a limit, above all of these: compound 2.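

In this assay, among these compounds, placing the oxime ether group on the double-bonded ring carbon in place of methoxymethyl gives a 3.2-fold lower number from compound 1 to compound 4 (0.50 log units; beyond the scatter), the first step that can be read from two measured compounds differing in one place. It shows that the number responds to the group at this ring carbon alone, with everything else in the shared core held the same, and that this response, though modest, is larger than the usual scatter. The pair does not separate the contributions of the nitrogen and the double bond that enter with the new group, and nothing given here bears on the cause of the step.

Compound 2 and compound 3 each differ from compound 1 and compound 4 in more than one place, so no further steps can be read from them. Going by these compounds, whether an amine, a carboxylic acid or a longer chain on this double-bonded ring carbon would move the number further, and in which direction, remains open.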